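The compounds below may be only part of what the source reports. "The series", "measured", "known", "first", "only" and "open" are said of these compounds alone.

Compound 2, `Cc1cccc(Nc2nc(C)c(C(=O)/C=C/c3ccccc3Cl)s2)c1`, stands in a functional assay on NCI-H460 cells (Homo sapiens) for cytotoxicity, read by MTT assay (a higher number here means a weaker inhibitor, a lower number a stronger inhibitor), only at a limit: in this assay compound 2 gives > 25000 nM, which is a limit of the assay and not a number. Going by the values given here, its one measured neighbour is compound 1, `COc1cccc(/C=C/C(=O)c2sc(Nc3cccc(C)c3)nc2C)c1`, differing by 2-chlorophenyl in place of 3-methoxyphenyl. In this assay compound 1 gives > 25000 nM, again a limit of the assay rather than a number. The step that the two limits leave unreadable from compound 1 to compound 2 therefore cannot be read; both values sit at the limit of > 25000 nM in this assay, at which 2 of the 2 values shown sit, so neither direction nor size is available from the measured pair.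

The next compound, compound 3, `Cc1nc(Nc2ccccc2)sc1C(=O)/C=C/c1ccccc1Cl`, differs from compound 2 by hydrogen in place of methyl on an aromatic carbon, the (3-methylphenyl)amino becoming anilino. Among the compounds with values here, no measured step bears on this change, and the only step in the set is unreadable. The expected step that the limit leaves unreadable from compound 2 to compound 3 is therefore essentially none, with the value most likely staying at the limit. Compound 3 is estimated at 30000 nM in this assay, within 8000 nM to 100000 nM, and will probably be reported only as a limit again.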

Compound 3, half-maximal inhibitory concentration: > 25000 nM
Compound 3 ended at the assay's limit; the forecaster's own chance of this, stated with the estimate: 80%; the middle value is on the limit's open side.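

In this assay compound 3 gives > 25000 nM, a limit of the assay and not a number. No step among compound 1, compound 2 and compound 3 can be read: the limit of > 25000 nM in this assay, at which 3 of the 3 values shown sit.

The compounds shown leave open whether any change on the shared core gives a readable value in this assay.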